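The source may hold more compounds than are shown below. What is called first, only, known or untested is meant among the compounds shown, and "the series" means these compounds.

Measured so far in a functional assay on HT-29 cells (Homo sapiens) for cytotoxicity, read by MTT assay, with a stated time of 24 h, tested at 1.6 ug/mL; a lower number here means a weaker effect, a higher number a stronger effect of the compound at the concentration tested:
compound 1, `Cn1cnnc1SCC(=O)Nc1ccc(-c2nc(-c3ccccc3)c(-c3ccccc3)n2C)cc1`: 40.8%
compound 2, `Cc1nnc(SCC(=O)Nc2ccc(-c3nc(-c4ccccc4)c(-c4ccccc4)n3C)cc2)s1`: 39.9%
compound 3, `Cn1c(-c2ccc(NC(=O)CN3CCN(c4ccccc4)CC3)cc2)nc(-c2ccccc2)c1-c1ccccc1`: 26%

Compound 3 stands lowest of these three numbers. The two compounds that carry a sulfur-linked heterocycle lie close together, a number 0.9 percentage points lower from compound 1 to compound 2 (within the scatter), while the move to the piperazine-bearing compound 3 is larger: a number 14.8 percentage points lower from compound 1 to compound 3 (beyond the scatter) and a number 13.9 percentage points lower from compound 2 to compound 3 (beyond the scatter).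

Compound 4, `Cn1c(-c2ccc(NC(=O)CN3CCN(Cc4ccc(Cl)cc4)CC3)cc2)nc(-c2ccccc2)c1-c1ccccc1`, keeps the piperazine of compound 3 and changes only its outer group: 4-chlorobenzyl in place of phenyl on an amine nitrogen in a ring.

Among the measured compounds shown here, none of the measured steps touches this place. The two steps that reach beyond the scatter swap the whole group on the saturated chain carbon bound to the carbonyl carbon, and the third step swaps the heterocycle on sulfur. Nothing here shows what replacing phenyl by 4-chlorobenzyl on the ring nitrogen does, so the expectation rests on compound 3 alone, with a wide range to allow for an unknown shift in either direction. The expected step is a number 1 percentage points higher from compound 3 to compound 4 (within the scatter), that is, none beyond the scatter. Compound 4 is therefore estimated at 27% in this assay, with a range from 12% to 45%.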

Compound 4, a percentage reported as activity, at one concentration (the size of the read-out at that concentration, not a potency): 16.4%
The estimate for compound 4 lay 10.6 percentage points above the measured number, within the range that was stated.
By their numbers in this assay, from the lowest: compounds 4 and 3 (each within the scatter of the next); then compounds 2 and 1 (each within the scatter of the next).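

In this assay, 4-chlorobenzyl in place of phenyl on an amine nitrogen in a ring gives a number 9.6 percentage points lower from compound 3 to compound 4 (within the scatter). Among the compounds shown here, this is the first direct look at this position, and at this single concentration the exchange does not separate the two compounds. No measurement shown here bears on why the two numbers stand as they do.

Going by these compounds, the exchange brings in a chlorine and a carbon link between the ring nitrogen and the aromatic ring at the same time, so the effect of each part remains open. Plain benzyl would separate the two, while a small group such as methyl or acetyl on that nitrogen would show whether any aromatic ring is needed there.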